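This account rests on a few compounds, and the source may have more. Where it says the series, first, only, none or still open, it means among the compounds named here.

Three related compounds have been measured in a functional assay on HT-29 cells (Homo sapiens) for antiproliferative activity, read by sulforhodamine B assay, with a stated time of 48 h; on this read-out lower numbers stand for stronger inhibition and higher numbers for weaker inhibition. Compound 1 `CCC(=O)Nc1cccc(S(=O)(=O)Oc2ccccc2C(C)C)c1` carries a propanoyl amide, and in this assay compound 1 gives 22000 nM. Compound 2 `CCCC(=O)Nc1cccc(S(=O)(=O)Oc2ccccc2C(C)C)c1` differs from compound 1 by methyl in place of hydrogen on a saturated chain carbon, two bonds along the chain from a carbonyl carbon; in this assay compound 2 gives 13000 nM, and the step of a 1.7-fold lower number from compound 1 to compound 2 (0.23 log units; within the scatter). Compound 3 `CC(=O)Nc1ccc(S(=O)(=O)Oc2ccccc2C(C)C)cc1` rests on a different core, and the difference between the two cores is not broken down here. In this assay compound 3 gives 23000 nM; set beside compound 1, the two values lie within the scatter of each other, so nothing can be read into that gap.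

Compound 4 `CCC(=O)Nc1ccc(S(=O)(=O)Oc2ccccc2C(C)C)cc1` has not yet been measured. It differs from compound 3 by methyl in place of hydrogen on a saturated chain carbon bound to a carbonyl carbon. For the measured compounds named here, this is the same kind of change as the one from compound 1 to compound 2, though not the same: there the methyl entered on a saturated chain carbon, two bonds along the chain from a carbonyl carbon, whereas here it enters on a saturated chain carbon bound to a carbonyl carbon. For compound 4 the expected step is a 1.5-fold lower number from compound 3 to compound 4 (0.19 log units; within the scatter), a small one, because the earlier step of a 1.7-fold lower number from compound 1 to compound 2 (0.23 log units; within the scatter) stayed within the scatter. Compound 4 is therefore estimated at 15000 nM in this assay. With a single prior example to rest on, the likely range for compound 4 is expected to run from 7000 nM to 35000 nM.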

Compound 4, half-maximal inhibitory concentration: 7400 nM
Beside the measured number, compound 4's estimate is 2.0-fold (0.31 log units) above it; measured number inside the range.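

In this assay, adding the methyl to the acetamido group, which turns it into propanoylamino, gives a 3.1-fold lower number from compound 3 to compound 4 (0.49 log units; beyond the scatter), a modest step that stands clear of the usual scatter of repeated measurements. Set beside the earlier step on the other core, this step cannot be told apart from it in size: the same change on two cores in this assay, a 1.7-fold lower number (0.23 log units; within the scatter) from compound 1 to compound 2 and a 3.1-fold lower number (0.49 log units; beyond the scatter) from compound 3 to compound 4, 1.8-fold (0.26 log units) apart, within the scatter of two such steps. For the compounds shown here, this fits the idea that the change carries over from one core to the other, but it does not prove it, since only one of the two steps clears the scatter, each core offers a single pair, and the methyl enters at a different place on the chain in each pair, so neither a shared effect nor a real difference between the cores is established.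

The compounds shown cover only a few short, unbranched acyl chains on the amide, so it remains open how a longer chain, a branched chain, or an amine or carboxylic acid at the end of the chain would behave on either core. A further open question is how the same change would read on each core at other places on the chain, which would show whether the trend holds beyond these two pairs.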